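A few compounds are considered here, and "the series" means these few. Any claim that something is new, unique, unknown or untested is made for them only; others in the source may bear on it.

Within the data shown here, in an ADME assay on the whole organism for pharmacokinetics, with Canis familiaris (Canis lupus familiaris) as the target, at a dose of 1 mg/kg by the oral route (a lower number here means less compound in the circulation, a higher number more compound in the circulation at the dose given), compound 1 `CCCC[C@H]1CN(c2cccc(C)c2C)C(=O)CN1Cc1cncn1Cc1ccc(C#N)cc1` gives 68.3 ng.h/mL, the lower of the two numbers available so far. Compound 2 `CCCC[C@H]1CN(c2cccc(C)c2C)C(=O)C(=O)N1Cc1cncn1Cc1ccc(C#N)cc1` gives 2000 ng.h/mL, a gap beyond the scatter. The next case is compound 3 `Cc1cccc(N2CCN(Cc3cncn3Cc3ccc(C#N)cc3)CC2=O)c1C`, which has hydrogen in place of butyl on a saturated ring carbon. No measured pair in the series isolates this change, so its size and direction in this assay are not shown by the data. The expectation therefore starts from compound 1 at 68.3 ng.h/mL, and compound 2 offers no direct guide. A small step with no firm direction, nothing beyond the scatter, is expected: a 1.2-fold higher number from compound 1 to compound 3 (0.07 log units; within the scatter). For compound 3 the estimated value is 80 ng.h/mL, with an expected range from 20 ng.h/mL to 320 ng.h/mL, kept wide since the series offers so little to go on.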

Compound 3, area under the concentration-time curve in the Canis familiaris assay: 559 ng.h/mL
For compound 3 the middle estimate is 7.0-fold (0.84 log units) below the measured one, outside the stated range (above it).
By their numbers in the Canis familiaris assay, from the lowest: compound 1; then compound 3; then compound 2.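

Among these compounds, in the Canis familiaris assay this position proves sensitive: hydrogen in place of butyl on a saturated ring carbon gives an 8.2-fold higher number from compound 1 to compound 3 (0.91 log units; beyond the scatter), the first step that isolates a single place. The same change also lowers the partition coefficient in a physicochemical assay for lipophilicity (a higher number here means a more lipophilic compound, a lower number a more polar compound), so in this one pair more compound in the circulation goes with a more polar compound: the measured partition coefficient of compound 1, > 3.7, and of compound 3, 2, a number at least 1.70 log units lower (beyond the scatter) In the physicochemical assay compound 1 gives > 3.7, which is a limit of the assay and not a number. In the physicochemical assay compound 3 gives 2 as a measured number.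

A single pair cannot separate the loss of the butyl chain itself from the drop in partition coefficient as the source of the higher number. As far as these compounds go, whether a shorter chain such as methyl or ethyl, or a butyl chain ending in an amine or a hydroxyl group, would sit nearer compound 1 or compound 3 stays open.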